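Toward compound 4: a saturated ring on the shared core

A few compounds are considered here, and "the series" means these few. Any claim that something is new, unique, unknown or untested is made for them only; others in the source may bear on it.

Compound 1 `Fc1ccc(-c2noc(C3CCc4c(nnn4-c4ccc(F)cc4)C3)n2)cc1` gives 106% in a functional assay on U2OS cells with metabotropic glutamate receptor 5 (Homo sapiens) as the target, read by calcium flux; on this read-out lower numbers stand for smaller maximal responses and higher numbers for larger maximal responses.
Compound 2 `CC(C)n1nnc2c1CCC(c1nc(-c3ccc(F)cc3)no1)C2` gives 98% in this assay.
Compound 3 `Cc1ccc(-c2noc(C3CCc4c(nnn4C(C)(C)C)C3)n2)cn1` gives 67% in this assay.

Among the three measured compounds, compound 3 stands lowest in this assay; its gap to compound 2, the nearest of the other two, and to compound 1, the furthest, both lie beyond the scatter. Among the measured compounds shown here, the one step measured so far, a number 8 percentage points lower from compound 1 to compound 2 (within the scatter), changes the group on the aromatic nitrogen of the shared core and stays within the scatter. Compound 4 `CC(C)(C)n1nnc2c1CCC(c1nc(C3CCCCC3)no1)C2` differs from compound 3 at another place: cyclohexyl in place of 6-methylpyridin-3-yl on an aromatic carbon. For the measured compounds named here, no measured step touches the group on this aromatic carbon of the five-membered aromatic ring, so the direction and size of the change in this assay cannot be read from the numbers in hand. Because the measured compounds span a range from 67% for compound 3 up to the level of compound 1, compound 4 is expected to fall somewhere inside that span. Compound 4 is estimated at 65%, with a range from 25% to 105%. This estimate means a step of a number 2 percentage points lower from compound 3 to compound 4 (within the scatter) is expected, which is within the scatter.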

Compound 4, largest response reached (reported as percent of maximum), in percent of the reference or control that the assay uses: 91%
Compound 4: the middle estimate sits 26 percentage points below what was measured; low and high end bracket the measured number.
By their numbers in this assay, from the lowest: compound 3; then compounds 4, 2 and 1 (each within the scatter of the next, the first and the last beyond it).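

Among the compounds shown here, with cyclohexyl in place of 6-methylpyridin-3-yl on this aromatic carbon of the five-membered aromatic ring, this assay shows a number 24 percentage points higher from compound 3 to compound 4 (beyond the scatter), the first measured step at this position and one that lies beyond the scatter. At least with the tert-butyl group on the aromatic nitrogen, this position therefore accepts a non-aromatic ring of carbon only, with no ring nitrogen or methyl group, and compound 4 still gives the larger maximal response. Nothing given here accounts for the size or direction of this step.

For the compounds shown here, the single step cannot show whether the aromatic ring, its nitrogen or its methyl group matters most, which unsubstituted phenyl or piperidin-4-yl at this position might help to separate. On these data alone, whether cyclohexyl brings a similar step with isopropyl on the aromatic nitrogen also remains open.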